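The source may hold more compounds than are shown below. What is called first, only, known or untested is meant among the compounds shown, and "the series" means these compounds.

Measured so far:
compound 1, `CCCCCCCC(=O)Nc1ccc2[nH]cc(C3CCN(C)CC3)c2n1`: 32 nM
compound 2, `COc1ccccc1C(=O)Nc1ccc2[nH]cc(C3CCN(C)CC3)c2n1`: 750 nM

Among the compounds with values here, in an assay for binding affinity to 5-hydroxytryptamine receptor 1B (Homo sapiens), read by radioligand binding (on this read-out lower numbers stand for stronger inhibition and higher numbers for weaker inhibition), compound 1 stands at the lower of the two numbers, and the only measured step, a 23-fold higher number from compound 1 to compound 2 (1.37 log units; beyond the scatter), is a large loss that comes from an aromatic ring replacing the heptyl chain on the carbonyl carbon. Compound 3, `CN1CCC(c2c[nH]c3ccc(NC(=O)c4ccncc4)nc23)CC1`, is not yet measured. It differs from compound 1 by pyridin-4-yl in place of heptyl on a carbonyl carbon. The step from compound 1 to compound 2 bears on this change, since it too exchanges the heptyl chain for a six-membered aromatic ring at the same carbonyl carbon, and it was large. A loss of similar size is therefore expected here, though the pyridine ring has not itself been tested, so the range is wide. Compound 3 is expected to give about 500 nM, between 100 nM and 2500 nM. This expected step amounts to a 16-fold higher number from compound 1 to compound 3 (1.19 log units; beyond the scatter).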

Compound 3, inhibition constant: 330 nM
Compound 3: the middle estimate sits 1.5-fold (0.18 log units) above what was measured; the range from low to high includes it.
By their numbers in this assay, from the lowest: compound 1; then compound 3; then compound 2.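

In this assay the change to pyridin-4-yl brings a 10-fold higher number from compound 1 to compound 3 (1.01 log units; beyond the scatter) and so shows that the loss at this carbonyl carbon is not confined to the 2-methoxyphenyl group, as both aromatic rings shown give higher numbers than the heptyl chain. The two rings are not equivalent, however: the exchange of 2-methoxyphenyl for pyridin-4-yl gives a 2.3-fold lower number from compound 2 to compound 3 (0.36 log units; beyond the scatter) and recovers a modest part of the loss, while compound 3 still remains well short of compound 1. No evidence is available to explain either step.

The compounds shown leave open whether a saturated ring such as cyclohexyl on this carbonyl carbon would behave like the heptyl chain or like the aromatic rings. They also leave open whether a shorter chain such as propyl would give a number near that of compound 1, and where unsubstituted phenyl or pyridin-3-yl would fall.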